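This account rests on a few compounds, and the source may have more. Where it says the series, first, only, none or still open, it means among the compounds named here.

Measured compounds and their results in a functional assay on HT-29 cells (Homo sapiens) for cytotoxicity, read by resazurin assay, with a stated time of 48 h; on this read-out lower numbers stand for an effect already at smaller amounts and higher numbers for an effect only at larger amounts of compound:

Compound 1, `O=C(/C=C/c1ccccc1)c1ccc(NC(=O)c2cccs2)cc1`: 28000 nM
Compound 2, `O=C(/C=C/c1ccccc1)c1ccc(NC(=O)c2ccccc2)cc1`: 36000 nM
Compound 3, `O=C(/C=C/c1cccc([N+](=O)[O-])c1)c1ccc(NC(=O)c2cccs2)cc1`: 2500 nM

These three compounds share one core and differ at two places. The first place is the amide-bearing end: compound 2 differs from compound 1 by phenyl in place of thiophen-2-yl on a carbonyl carbon, and this gave a 1.3-fold higher number from compound 1 to compound 2 (0.11 log units; within the scatter), so the two numbers are not distinguishable in this assay. Within the data shown here, the second place is the far ring: compound 3 differs from compound 1 by nitro in place of hydrogen on an aromatic carbon, and this gave an 11-fold lower number from compound 1 to compound 3 (1.05 log units; beyond the scatter), the only clear step among the three.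

Compound 4, `O=C(/C=C/c1cccc([N+](=O)[O-])c1)c1ccc(NC(=O)c2ccccc2)cc1`, is not yet measured. It differs from compound 3 by phenyl in place of thiophen-2-yl on a carbonyl carbon. Since the place is described in the same words as for the step from compound 1 to compound 2, this is the same change, now made on a core that carries the nitro group. The expectation for compound 4 in this assay is therefore a step of about a 1.3-fold higher number from compound 3 to compound 4 (0.11 log units; within the scatter), resting on the fact that the same change earlier gave only a 1.3-fold higher number from compound 1 to compound 2 (0.11 log units; within the scatter), a difference within the scatter, and that compound 3 brings 2500 nM as the starting point. Compound 4 is thus expected to give about 3200 nM, with a likely range from 1500 nM to 7000 nM.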

Compound 4, half-maximal effective concentration: 3900 nM
For compound 4 the middle estimate is 1.2-fold (0.09 log units) below the measured one; the range from low to high includes it.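

The swap of thiophen-2-yl for phenyl on a carbonyl carbon behaved alike on both cores, giving a 1.6-fold higher number from compound 3 to compound 4 (0.19 log units; within the scatter) in this assay and remaining a step too small to tell apart from the scatter: the same change on two cores in this assay, a 1.3-fold higher number (0.11 log units; within the scatter) from compound 1 to compound 2 and a 1.6-fold higher number (0.19 log units; within the scatter) from compound 3 to compound 4, 1.2-fold (0.08 log units) apart, within the scatter of two such steps.

The nitro group also carried over, giving a 9.2-fold lower number from compound 2 to compound 4 (0.97 log units; beyond the scatter) on the core with phenyl, much as it did on the core with thiophen-2-yl: the same change on two cores in this assay, an 11-fold lower number (1.05 log units; beyond the scatter) from compound 1 to compound 3 and a 9.2-fold lower number (0.97 log units; beyond the scatter) from compound 2 to compound 4, 1.2-fold (0.08 log units) apart, within the scatter of two such steps.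

Within these four compounds, then, each change acts about the same whichever form the other place takes, but a set this small does not show that this would hold for other groups, other cores or other assays.

Going by these compounds, it remains open whether another group on that aromatic carbon, such as an amine, a carboxylic acid or a methoxy group, would give a step of the same size as nitro. On these data alone, it is equally open whether a longer chain or a saturated ring on the carbonyl carbon, in place of phenyl or thiophen-2-yl, would leave the number as little changed as this swap did.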